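The source may report more compounds than this note shows. Statements on the series, on what has been measured and on what is new or still open speak of the compounds shown alone.

Working notes on the series.

Compound 1 `C[C@@]1(O)CC(=O)OC(CSc2nc(-c3ccccc3)c(-c3ccccc3)[nH]2)C1` is measured in an assay on microsomes from liver for inhibition of sterol O-acyltransferase 1 (Rattus norvegicus) (on this read-out lower numbers stand for stronger inhibition and higher numbers for weaker inhibition), at 170 nM. Two further members of the series carry the same lactone side chain on differently substituted cores. Compound 3 `C[C@@]1(O)CC(=O)OC(CSc2nc(-c3ccc(Cl)cc3)c(-c3ccc(Cl)cc3)[nH]2)C1` gives 180 nM in this assay, and compound 2 `COc1ccc(-c2nc(SCC3C[C@@](C)(O)CC(=O)O3)[nH]c2-c2ccc(OC)cc2)cc1` gives 340 nM in this assay. Both of those numbers lie within the usual scatter of the value of compound 1, so the three measured compounds cannot be separated from one another on this read-out; compound 1 simply carries the smallest of three numbers that are, for practical purposes, indistinguishable.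

Compound 4 `O=C1CCCC(CSc2nc(-c3ccccc3)c(-c3ccccc3)[nH]2)O1` has not yet been measured. Relative to compound 1 it shows the following change: a group of 7 heavy atoms (5 carbon, 2 oxygen; one six-membered non-aromatic ring with 1 hetero atom) in place of a group of 9 heavy atoms (6 carbon, 3 oxygen; one six-membered non-aromatic ring with 1 hetero atom), on a saturated chain carbon bound to a sulfur. Among the measured compounds shown here, no pair of measured compounds differs by this change, or by any change at this part of the molecule, so the data give no direct calibration of its effect. The three measured compounds all keep the hydroxylated, methylated lactone, and all sit close together, which says nothing about what happens when that ring is simplified.

For compound 4 the step of a 2.4-fold higher number from compound 1 to compound 4 (0.37 log units; beyond the scatter) is expected to be a modest weakening at most, not clearly beyond the scatter, with compound 4 estimated at 400 nM in this assay, within a range of 150 nM to 1200 nM.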

Compound 4, half-maximal inhibitory concentration: 740 nM
Compound 4: the middle estimate sits 1.9-fold (0.27 log units) below what was measured; the measured number falls inside the stated range.
By their numbers in this assay, from the lowest: compounds 1, 3 and 2 (each within the scatter of the next); then compound 4.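

Among the compounds shown here, the step of a 4.4-fold higher number from compound 1 to compound 4 (0.64 log units; beyond the scatter) in this assay is the first reading at this position, on a saturated chain carbon bound to a sulfur, and it lies beyond the scatter, whereas the three earlier compounds, which all share one side chain, could not be separated from one another. The read-out therefore does respond to this part of the molecule when the group of 9 heavy atoms gives way to the group of 7 heavy atoms on an unchanged core. The group that leaves has 1 hydrogen-bond donor and 3 hydrogen-bond acceptors, the group that enters has 0 hydrogen-bond donors and 2 hydrogen-bond acceptors, and no measurement at hand ties the step to any one of these differences.

From the compounds shown here alone, it remains open whether a ring keeping only the hydroxyl or only the methyl would sit with compound 1 or with compound 4, and whether the same change gives a similar step on the cores of compound 2 and compound 3. Going by these compounds, how an amine, a carboxylic acid or a longer chain would read at this place also remains open.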